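From phenyl to pyridin-4-yl on a shared core

This account rests on a few compounds, and the source may have more. Where it says the series, first, only, none or still open, it means among the compounds named here.

Compound 1 `COC(=O)c1ccc(N2CC3(CCN(C(=O)c4cc(C)c5[nH]ncc5c4)CC3)CC2=O)cc1`: > 10000 nM
Compound 2 `O=C(c1ccc2[nH]c(-c3ccccc3)nc2c1)N1CCC2(CC1)CC(=O)N(c1ccc(C(F)(F)F)cc1)C2`: 2050 nM

Going by the values given here, in a functional assay on SW-620 cells (Homo sapiens) for antiproliferative activity, read by MTT assay, with a stated time of 48 h (on this read-out lower numbers stand for stronger inhibition and higher numbers for weaker inhibition), compound 2 gives 2050 nM, the only actual number so far. For compound 1 the result > 10000 nM is a limit of the assay. Compound 3 `O=C(c1ccc2[nH]c(-c3ccncc3)nc2c1)N1CCC2(CC1)CC(=O)N(c1ccc(C(F)(F)F)cc1)C2` departs from compound 2 in one place: pyridin-4-yl in place of phenyl on an aromatic carbon, with pyridin-4-yl in place of phenyl on an aromatic carbon. Among the compounds with values here, no measured pair tests this change, so the expectation in this assay is only a modest loss of inhibition. The estimated step of a 1.5-fold higher number from compound 2 to compound 3 (0.17 log units; within the scatter) is small and points towards weaker inhibition. For compound 3 the expected value is 3000 nM, with an estimated range from 900 nM to 10000 nM.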

Compound 3, half-maximal inhibitory concentration: 7240 nM
For compound 3 the middle estimate is 2.4-fold (0.38 log units) below the measured one, within the range that was stated.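

In this assay, going by these compounds alone, the only step that can be read at this position, on an aromatic carbon between two ring nitrogen atoms, is a 3.5-fold higher number from compound 2 to compound 3 (0.55 log units; beyond the scatter). Pyridin-4-yl in place of phenyl brings one ring nitrogen and one hydrogen-bond acceptor, and inhibition falls, although compound 3 still gives a number. Only compound 1 stands at a limit of the assay: the limit of > 10000 nM in this assay, at which 1 of the 3 values shown sits.

Going by these compounds, it remains open whether the ring nitrogen would cost as much as pyridin-3-yl or pyridin-2-yl. On these data alone, how a methyl group or an amine would read at this position also remains open.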